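Aryl Amide Exchange on a Potassium Channel Binder

The source may report more compounds than this note shows. Statements on the series, on what has been measured and on what is new or still open speak of the compounds shown alone.

Compound 1 `COCC(=O)Nc1c(C(O)(C(F)(F)F)C(F)(F)F)ccc2ccccc12` gives 213 nM in an assay on LtK cells with ATP-sensitive inward rectifier potassium channel 11 (Homo sapiens) as the target; on this read-out higher numbers stand for an effect only at larger amounts of compound and lower numbers for an effect already at smaller amounts.
Compound 2 `O=C(Nc1c(C(O)(C(F)(F)F)C(F)(F)F)ccc2ccccc12)c1ccc(F)cc1` gives 70 nM in this assay.

Going by the values given here, compound 2 holds the lowest of the two numbers, and its only neighbour is compound 1: a 3.0-fold lower number from compound 1 to compound 2 (0.48 log units; beyond the scatter). Compound 3 `O=C(Nc1c(C(O)(C(F)(F)F)C(F)(F)F)ccc2ccccc12)c1cccs1` is the next step, differing from compound 2 in one place: thiophen-2-yl in place of 4-fluorophenyl on a carbonyl carbon. Among the compounds with values here, the single measured step concerned methoxymethyl against 4-fluorophenyl on the same carbonyl carbon, so it bears on this change only loosely; both groups in the new step are aromatic rings. The step from compound 2 to compound 3 is therefore expected to stay within the scatter, a 1.3-fold higher number from compound 2 to compound 3 (0.11 log units; within the scatter). Compound 3 is estimated at 90 nM, ranging from 35 nM to 250 nM.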

Compound 3, half-maximal effective concentration: 12 nM
For compound 3 the middle estimate is 7.5-fold (0.88 log units) above the measured one, outside the stated range (below it).
By their numbers in this assay, from the lowest: compound 3; then compound 2; then compound 1.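

At this carbonyl carbon, the identity of the aromatic ring matters in this assay, and not only the presence of one: thiophen-2-yl in place of 4-fluorophenyl gives a 5.8-fold lower number from compound 2 to compound 3 (0.77 log units; beyond the scatter). Measured against the methoxymethyl amide, thiophen-2-yl gives an 18-fold lower number from compound 1 to compound 3 (1.25 log units; beyond the scatter). No evidence on the cause of these differences is available. As far as these compounds go, it remains open whether the ring's sulfur or its smaller size goes with the lower number, and whether furan-2-yl, thiophen-3-yl or a pyridine ring on the same carbonyl carbon would match compound 3.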